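This account rests on a few compounds, and the source may have more. Where it says the series, first, only, none or still open, it means among the compounds named here.

Within the data shown here, in a functional assay on DU-145 cells (Homo sapiens) for cytotoxicity, read by sulforhodamine B assay, with a stated time of 48 h (a higher number here means a weaker inhibitor of growth, a lower number a stronger inhibitor of growth), compound 2 `COc1ccc(C(=O)c2cc(OC)c(OC)c(OC)c2)c(OC)c1O` gives 20.9 nM and holds the lowest number so far, while compound 1 `COc1cc(C(=O)c2ccc(OC)c(O)c2OC)cc(OC)c1O` gives 818 nM on the far side of a gap beyond the scatter. The next structure is compound 3 `COc1ccc(C(=O)c2cc(OC)c(OC)c(OC)c2)c(OC)c1NC(C)=O` with acetamido in place of hydroxy on an aromatic carbon, ortho to two methoxy groups and meta to a large group: acetamido in place of hydroxy on an aromatic carbon is the counted difference. Among the measured compounds shown here, the one measured step of a 39-fold lower number from compound 1 to compound 2 (1.59 log units; beyond the scatter) is large but concerns methyl in place of hydrogen on an oxygen on an aromatic ring at a different place. It gives no direct reading of this change, and no replacement of this hydroxy has been measured. That step shows only that a single substitution can move the series strongly. With compound 2 at 20.9 nM as the lowest number, a moderate to large step toward a higher number is expected in this assay with wide uncertainty. The estimate for compound 3 is 250 nM with an expected range from 50 nM to 1500 nM in this assay. The expected move is a 12-fold higher number from compound 2 to compound 3 (1.08 log units; beyond the scatter) on this estimate.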

Compound 3, concentration for 50% growth inhibition: 292 nM
Estimate against measurement, compound 3: 1.2-fold (0.07 log units) below, and the stated range covers the measured number.
By their numbers in this assay, from the lowest: compound 2; then compound 3; then compound 1.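

Acetamido in place of hydroxy gives a 14-fold higher number from compound 2 to compound 3 (1.15 log units; beyond the scatter) in this assay and is the first direct reading at this hydroxy, since the earlier step concerned a different place on the core. This position therefore also moves the series strongly, and the replacement tested here goes toward a higher number. Hydroxy counts 1 heavy atom and acetamido 4 heavy atoms, while the hydrogen-bond donor and acceptor counts match, and no measured data explain the result.

With one replacement shown at this carbon, the effect of the added atoms cannot be separated from that of the amide itself. As far as these compounds go, an amine or a methoxy group on this carbon, or a longer acyl chain on the nitrogen of the acetamido group, remains open.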